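Benzyl substituent changes on the shared core

A few compounds are considered here, and "the series" means these few. Any claim that something is new, unique, unknown or untested is made for them only; others in the source may bear on it.

Compound 3 `COc1ccc(Cn2nnc(-c3ccccc3)c2C(=O)N[C@@H](C)c2ccc(C(=O)O)cc2)cc1F` shows the highest number of the three measured in a functional assay on CHO cells for antagonist activity at prostaglandin E2 receptor EP4 subtype (Homo sapiens), read by calcium flux, with a stated time of 15 min (on this read-out higher numbers stand for weaker inhibition and lower numbers for stronger inhibition), giving 29.8 nM, though its gap to compound 1 is within the scatter. Compound 1 `C[C@H](NC(=O)c1c(-c2ccccc2)nnn1Cc1cccc(C(F)(F)F)c1)c1ccc(C(=O)O)cc1` gives 23 nM and compound 2 `COc1ccc(Cn2nnc(-c3ccccc3)c2C(=O)N[C@@H](C)c2ccc(C(=O)O)cc2)cc1` gives 9.3 nM. The step of a 3.2-fold higher number from compound 2 to compound 3 (0.51 log units; beyond the scatter) lies beyond the scatter, the step of a 1.3-fold higher number from compound 1 to compound 3 (0.11 log units; within the scatter) within it, and the step of a 2.5-fold lower number from compound 1 to compound 2 (0.39 log units; beyond the scatter) is modest. Compound 4 `COc1ccc(Cn2nnc(-c3ccccc3)c2C(=O)N[C@@H](C)c2ccc(C(=O)O)cc2)cc1OC` differs from compound 3 by methoxy in place of fluoro on an aromatic carbon. Among the compounds with values here, the step from compound 2 to compound 3 is the one that bears on this, covering the fluoro now leaving; no measured step introduces methoxy at that carbon. A modest decrease is expected, a 2.1-fold lower number from compound 3 to compound 4 (0.33 log units; beyond the scatter), partly undoing that step. Compound 4 is therefore estimated at 14 nM, within 5 nM to 40 nM.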

Compound 4, half-maximal inhibitory concentration: 119 nM
Beside the measured number, compound 4's estimate is 8.5-fold (0.93 log units) below it; the whole stated range lies below it.
By their numbers in this assay, from the lowest: compound 2; then compounds 1 and 3 (each within the scatter of the next); then compound 4.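

In this assay, methoxy on the aromatic carbon ortho to a methoxy group is not tolerated like fluoro (a 4.0-fold higher number from compound 3 to compound 4 (0.60 log units; beyond the scatter)), and against hydrogen there the change is large (a 13-fold higher number from compound 2 to compound 4 (1.11 log units; beyond the scatter)). The 3,4-dimethoxyphenyl group also gives a higher number than 3-(trifluoromethyl)phenyl (a 5.2-fold higher number from compound 1 to compound 4 (0.71 log units; beyond the scatter)). No supporting evidence bears on why methoxy behaves this way here.

Going by these compounds, whether hydroxy, an amine or a longer ether such as ethoxy at this carbon would track fluoro or methoxy remains open. Also open, on these data alone, is whether methoxy on other carbons of this ring gives the same rise.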